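The source may report more compounds than this note shows. Statements on the series, on what has been measured and on what is new or still open speak of the compounds shown alone.

Measured compounds in an ADME assay on RAW264.7 cells (Mus musculus) for cytotoxicity, read by MTT assay, with a stated time of 72 h, tested at 50 uM; on this read-out higher numbers stand for more inhibition at the one concentration tested (going by the name of the read-out) and lower numbers for less inhibition:

Compound 1 `CCOC(=O)c1sc(-c2ccccc2)nc1N1CCC(NCc2ccc(Cl)c(Cl)c2)CC1`: 18.1%
Compound 2 `CCOC(=O)c1sc(-c2ccccc2)nc1N1CCC(NCc2ccc(Cl)cc2Cl)CC1`: 9.43%
Compound 3 `CCOC(=O)c1sc(-c2ccncc2)nc1N1CCC(NCc2ccc(Cl)c(Cl)c2)CC1`: 32.2%

Compounds 1 and 2 share one core and differ only in the change (2,4-dichlorophenyl in place of 3,4-dichlorophenyl on a saturated chain carbon bound to an amine nitrogen); this change gave a number 8.7 percentage points lower from compound 1 to compound 2 (within the scatter). Compound 3 carries a different core, the difference being (pyridin-4-yl in place of phenyl on an aromatic carbon), and this change gave a number 14.1 percentage points higher from compound 1 to compound 3 (beyond the scatter), leaving compound 3 with the highest number of the three.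

Compound 4 `CCOC(=O)c1sc(-c2ccncc2)nc1N1CCC(NCc2ccc(Cl)cc2Cl)CC1` is not yet measured in this assay. It differs from compound 3 by 2,4-dichlorophenyl in place of 3,4-dichlorophenyl on a saturated chain carbon bound to an amine nitrogen, which is the same change as that from compound 1 to compound 2, made at the same place on the other core. Going by the values given here, the only guide is that step, which stayed within the scatter. The step from compound 3 to compound 4 is therefore expected to be a number 8.2 percentage points lower from compound 3 to compound 4 (within the scatter). Compound 4 is estimated to give 24%, most likely between 10% and 38%.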

Compound 4, a percentage reported as inhibition, at one concentration (the size of the read-out at that concentration, not a potency): 18.4%
Compound 4: the middle estimate sits 5.6 percentage points above what was measured; the range from low to high includes it.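

In this assay, 2,4-dichlorophenyl in place of 3,4-dichlorophenyl gave a number 13.8 percentage points lower from compound 3 to compound 4 (beyond the scatter), and this step agrees with the one on the other core: the same change on two cores in this assay, a number 8.7 percentage points lower (within the scatter) from compound 1 to compound 2 and a number 13.8 percentage points lower (beyond the scatter) from compound 3 to compound 4, 5.1 percentage points apart, within the scatter of two such steps Pyridin-4-yl in place of phenyl gave a number 9 percentage points higher from compound 2 to compound 4 (within the scatter), and this step also agrees with its earlier counterpart: the same change on two cores in this assay, a number 14.1 percentage points higher (beyond the scatter) from compound 1 to compound 3 and a number 9 percentage points higher (within the scatter) from compound 2 to compound 4, 5.1 percentage points apart, within the scatter of two such steps Each change therefore carried across these two cores with a size that agrees within the scatter, but each comparison rests on a single pair of steps and does not show that the same would hold on any further core.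

The compounds shown leave open how the read-out responds to a carboxylic acid or an amide in place of the ethyl ester. They also leave open what a pyridin-3-yl group or a benzyl group with a single chlorine would give.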